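The compounds below may be only part of what the source reports. "The series", "measured", "known", "first", "only" and "open" are said of these compounds alone.

Measured so far:
- Compound 1, `COc1ccc(NC(=O)C2=C(C)NC(=O)NC2c2cccc([N+](=O)[O-])c2)cc1`: 64 ug/mL
- Compound 2, `COc1ccc(NC(=O)C2=C(C)NC(=S)NC2c2cccc([N+](=O)[O-])c2)cc1`: 80 ug/mL
- Compound 3, `COc1ccc(NC(=O)C2=C(C)NC(=O)NC2c2cccc(Cl)c2)cc1`: 254 ug/mL

These numbers come from an ADME assay on Vero cells (Chlorocebus sabaeus) for cytotoxicity, read by sulforhodamine B assay, with a stated time of 3 days; a lower number here means that less compound is tolerated, a higher number that more compound is tolerated. Compound 1 and compound 2 share most of their structure, but the difference between the two cores is not broken down here; their values sit within the usual scatter of each other, so nothing separates them. Compound 3 differs from compound 1 only by chloro in place of nitro on an aromatic carbon, and that single change made a 4.0-fold higher number from compound 1 to compound 3 (0.60 log units; beyond the scatter), a step beyond the scatter. Compound 4, `COc1ccc(NC(=O)C2=C(C)NC(=S)NC2c2cccc(Cl)c2)cc1`, is not yet measured. It differs from compound 2 by chloro in place of nitro on an aromatic carbon, the same change at the same place that turned compound 1 into compound 3, now applied on the core of compound 2 instead. For compound 2 to compound 4 the expected step is a 3.5-fold higher number from compound 2 to compound 4 (0.54 log units; beyond the scatter), because the same change once gave a 4.0-fold higher number from compound 1 to compound 3 (0.60 log units; beyond the scatter) on a closely related core. Compound 4 is therefore expected to give 280 ug/mL, with a likely range from 120 ug/mL to 600 ug/mL.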

Compound 4, half-maximal cytotoxic concentration: 270 ug/mL
Compound 4: middle estimate off by 1.0-fold (0.02 log units), on the high side, and the stated range covers the measured number.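

In this assay, replacing nitro with chloro on the aromatic ring gave a 3.4-fold higher number from compound 2 to compound 4 (0.53 log units; beyond the scatter), meaning that more compound was tolerated by the cells. Set beside the earlier step, the change carried over from one core to the other at much the same size: the same change on two cores in this assay, a 4.0-fold higher number (0.60 log units; beyond the scatter) from compound 1 to compound 3 and a 3.4-fold higher number (0.53 log units; beyond the scatter) from compound 2 to compound 4, 1.2-fold (0.07 log units) apart, within the scatter of two such steps. This shows that the swap from 3-nitrophenyl to 3-chlorophenyl behaved alike on these two closely related cores, but it rests on a single pair of steps, so it does not show that the same would happen on any other core, nor does it explain why the number rises.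

The compounds shown leave open what other groups in that same place would do, such as an amine, a carboxylic acid or a longer chain. They also leave open whether chloro would give a step of this size if it sat elsewhere on the ring.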